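Removing the Chloro Group from Compound 1

A few compounds are considered here, and "the series" means these few. Any claim that something is new, unique, unknown or untested is made for them only; others in the source may bear on it.

Compound 1 `COc1c(/C=C2/C(=O)Nc3ccc(Cl)cc32)c2ccccc2n1-c1ccccc1` stands with the higher of the two numbers recorded in a functional assay on cells (Cancer cell lines, Homo sapiens) for cytotoxicity, with a stated time of 48 h (on this read-out lower numbers stand for stronger inhibition of growth and higher numbers for weaker inhibition of growth), where compound 1 gives 4270 nM. Compound 2 `O=C1/C(=C/c2c(Cl)[nH]c3ccccc23)c2ccccc2N1Cc1ccccc1` sits alongside it: in this assay compound 2 gives 4170 nM, a gap within the scatter, so no order between the two can be read. From the compounds shown here alone, compound 3 `COc1c(/C=C2/C(=O)Nc3ccccc32)c2ccccc2n1-c1ccccc1` is untested; it differs from compound 1 by hydrogen in place of chloro on an aromatic carbon. Within the data shown here, with no measured step between compounds to lean on, the step of a 1.4-fold higher number from compound 1 to compound 3 (0.15 log units; within the scatter) is expected to be small, toward weaker inhibition at most, and may not exceed the scatter. Compound 3 is therefore estimated at 6000 nM, within 2500 nM to 15000 nM.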

Compound 3, concentration for 50% growth inhibition: 1230 nM
Estimate against measurement, compound 3: 4.9-fold (0.69 log units) above, outside the stated range (below it).
By their numbers in this assay, from the lowest: compound 3; then compounds 2 and 1 (each within the scatter of the next).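

In this assay the chloro group on this aromatic carbon proves not to be required for growth inhibition: hydrogen in its place gives a 3.5-fold lower number from compound 1 to compound 3 (0.54 log units; beyond the scatter) and so moves the shared core toward stronger inhibition. Among these compounds, this is the first sign that the position responds to a change at all. Nothing measured here explains the direction of this step.

The compounds shown leave open how an amine or a carboxylic acid on this carbon would compare with hydrogen or chloro. They also leave open whether removing chloro has the same effect on a different core.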